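The source may hold more compounds than are shown below. What is called first, only, known or untested is meant among the compounds shown, and "the series" means these compounds.

Compound 1 `CC1(C)C=C(n2ccccc2=O)c2cc(C(=O)c3ccco3)ccc2O1`: 6.49
Compound 2 `CC1(C)C=C(n2ccccc2=O)c2cc(C(=O)c3ccccc3C(F)(F)F)ccc2O1`: 6.76

In a functional assay (aorta) with Rattus norvegicus as the target (a lower number here means a less potent compound, a higher number a more potent compound, by a factor of ten per unit of this negative logarithm), compound 2 gives 6.76, and compound 1 gives 6.49; the two numbers lie within the scatter of each other, so neither can be called the more potent. For the measured compounds named here, the one measured step, a number 0.27 log units higher from compound 1 to compound 2 (within the scatter), exchanges one aromatic group for another on the carbonyl carbon and stays within the scatter.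

Compound 3 `CC1(C)C=C(n2ccccc2=O)c2cc(C=O)ccc2O1` differs from compound 2 in one place: hydrogen in place of 2-(trifluoromethyl)phenyl on a carbonyl carbon. Going by the values given here, no measured step removes the aromatic group from the carbonyl carbon altogether, so the series gives no direct guide for this change; the only step available speaks to an exchange of aromatic groups, not their loss. A downward step a number 0.86 log units lower from compound 2 to compound 3 (beyond the scatter) in this assay is expected, with wide uncertainty. Compound 3 is estimated at 5.9 in this assay, with a range from 5.2 to 6.6.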

Compound 3, logarithm of the reciprocal of the active concentration, log(1/C): 6.91
Estimate against measurement, compound 3: 1.01 log units below; the measured number lies above the stated range.
By their numbers in this assay, from the lowest: compounds 1, 2 and 3 (each within the scatter of the next, the first and the last beyond it).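

In this assay, taking the aromatic group off the carbonyl carbon altogether leaves no readable loss: a number 0.15 log units higher from compound 2 to compound 3 (within the scatter). Set against the furan-2-yl compound, the same replacement gives a number 0.42 log units higher from compound 1 to compound 3 (beyond the scatter), a modest gain. Among these three compounds, then, an aromatic group on the carbonyl carbon is not needed for the response, and hydrogen there does at least as well as either aromatic group shown. Nothing available bears on why this is so.

The compounds shown leave open whether the carbonyl itself is needed, which a nitrile or a carboxylic acid in its place would address. They also leave open how a small group such as methyl on the carbonyl carbon would compare with hydrogen.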